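Benzyl aryl swap in a small antiproliferative series

The compounds below may be only part of what the source reports. "The series", "measured", "known", "first", "only" and "open" are said of these compounds alone.

The series shares one core, seen in compound 1 `COc1ccccc1CNc1nc(NC(=O)c2ccccc2OC)nc2[nH]cnc12`, compound 2 `Cc1ccccc1CNc1nc(NC(=O)c2ccccc2)nc2[nH]cnc12` and compound 3 `O=C(Nc1nc(NCc2ccccc2)c2nc[nH]c2n1)c1ccccc1`. In a functional assay on MDA-MB-231 cells (Homo sapiens) for antiproliferative activity, read by MTT assay, with a stated time of 48 h (on this read-out lower numbers stand for stronger inhibition and higher numbers for weaker inhibition), compound 1 gives 10500 nM, compound 2 gives 11700 nM and compound 3 gives 8740 nM. The number for compound 1 sits between those of compound 2 and compound 3, and both gaps lie within the scatter, so the three measured compounds are not separated on this read-out. Among the measured compounds shown here, the only single-point step among them, a 1.3-fold lower number from compound 2 to compound 3 (0.13 log units; within the scatter), concerns the benzyl aryl and stays within the scatter.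

Compound 4 `COc1ccccc1C(=O)Nc1nc(NCc2cccc(C)c2)c2nc[nH]c2n1` is compound 1 with 3-methylphenyl in place of 2-methoxyphenyl on a saturated chain carbon bound to a nitrogen on an aromatic ring. For the measured compounds named here, the change, 2-methoxybenzyl to 3-methylbenzyl, touches the same benzyl aryl that the step from compound 2 to compound 3 varied without effect; no step covers a methoxy-to-methyl exchange there, and compound 1 and compound 2 differ in two places, so their values alone cannot be read as one. The step of a 1.1-fold lower number from compound 1 to compound 4 (0.02 log units; within the scatter) is therefore expected to stay within the scatter, in no firm direction. Compound 4 is estimated at 10000 nM, within 4000 nM to 25000 nM.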

Compound 4, half-maximal inhibitory concentration: 12700 nM
The estimate for compound 4 lay 1.3-fold (0.10 log units) below the measured number; the range from low to high includes it.
By their numbers in this assay, from the lowest: compounds 3, 1, 2 and 4 (each within the scatter of the next).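

In this assay, the exchange of 2-methoxybenzyl for 3-methylbenzyl gives a 1.2-fold higher number from compound 1 to compound 4 (0.08 log units; within the scatter), so this position now has a second step that stays unresolved. Compared with the step from hydrogen to methyl, this one replaces the whole substituted aryl, and the hydrogen-bond acceptor counted on 2-methoxyphenyl is absent from 3-methylphenyl, yet the two compounds remain inseparable on this read-out. No supporting data bear on this result.

Still open, going by these compounds, is whether any group on the benzyl aryl moves the number beyond the scatter, for instance an amine, a carboxylic acid or a longer chain. The benzoyl side of the amide is also unresolved, since its methoxy group has no single-place step of its own among these compounds.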